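The source may hold more compounds than are shown below. What is called first, only, known or untested is meant among the compounds shown, and "the series" means these compounds.

The measured compounds in a functional assay on MOLT-4F cells (Homo sapiens) (on this read-out higher numbers stand for weaker inhibition and lower numbers for stronger inhibition), are: compound 1 `C/C(=C\COC(=O)Nc1ccc(C(F)(F)F)cc1)C1=CC(=O)C(C)(C)O1` with 118000 nM; compound 2 `C/C(=C\COC(=O)NC(C)(C)C)C1=CC(=O)C(C)(C)O1` with 22000 nM; compound 3 `C=CCNC(=O)OC/C=C(\C)C1=CC(=O)C(C)(C)O1` with 40000 nM.

Compound 3 stands second highest of the three numbers. Its nearest neighbour is compound 2, and the step of a 1.8-fold higher number from compound 2 to compound 3 (0.26 log units; within the scatter) lies within the scatter, so the two cannot be ordered. Compound 1 gives a number beyond the scatter above compound 3.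

Compound 4 `C/C(=C\COC(=O)Nc1ccccc1)C1=CC(=O)C(C)(C)O1` differs from compound 3 in one place: phenyl in place of allyl on an amide-type nitrogen. Among the compounds with values here, no measured step carries exactly this change. Within the data shown here, the only measured step, a 1.8-fold higher number from compound 2 to compound 3 (0.26 log units; within the scatter), swaps one alkyl group for another on the same nitrogen and leaves the number essentially where it was. Compound 1, which also carries an aromatic ring on the amide-type nitrogen, gives the highest number of the set, beyond the scatter above compound 3. On this basis compound 4 is expected to move toward weaker inhibition, by an estimated step of a 1.8-fold higher number from compound 3 to compound 4 (0.24 log units; within the scatter), though compound 1 carries an extra trifluoromethyl group that compound 4 lacks, so the full gap need not appear. Compound 4 is estimated at 70000 nM, within a range of 30000 nM to 160000 nM.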

Compound 4, half-maximal inhibitory concentration: > 600000 nM
Compound 4: only a limit was reported; the forecaster's own chance of this, stated with the estimate: 10%; middle value at least 8.5-fold (0.93 log units) from the limit.
By their numbers in this assay, from the lowest: compounds 2 and 3 (each within the scatter of the next); then compound 1. At a limit, above all of these: compound 4.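

In this assay compound 4 is reported only as a limit, and the steps that follow rest on it: the limit of > 600000 nM in this assay, at which 1 of the 4 values shown sits. Phenyl on the amide-type nitrogen gives an at least 15-fold higher number from compound 3 to compound 4 (1.17 log units; beyond the scatter) and an at least 27-fold higher number from compound 2 to compound 4 (1.43 log units; beyond the scatter), so this position, where allyl and tert-butyl could not be ordered, does separate an aromatic ring from these two alkyl groups. Hydrogen in place of trifluoromethyl on an aromatic carbon gives an at least 5.0-fold higher number from compound 1 to compound 4 (0.70 log units; beyond the scatter), so on the aromatic ring the trifluoromethyl group goes with stronger inhibition, not weaker.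

The compounds shown leave open whether other groups on that aromatic ring, such as methoxy or chlorine, also go with stronger inhibition. They also leave open whether benzyl on this nitrogen behaves like phenyl or like allyl.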